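A few compounds are considered here, and "the series" means these few. Any claim that something is new, unique, unknown or untested is made for them only; others in the source may bear on it.

Measured in a functional assay on MCF7 cells (Homo sapiens) for antiproliferative activity, read by MTT assay, with a stated time of 48 h; a higher number here means a weaker inhibitor, a lower number a stronger inhibitor:
Compound 1 `COc1cc(-c2cccc3nc(-c4ccc(Cl)cc4)oc23)cc(OC)c1OC`: > 25000 nM (a limit)
Compound 2 `COc1cc(-c2cccc3nc(-c4cccc(O)c4)oc23)cc(OC)c1OC`: > 25000 nM (a limit)

Compound 2 has no exact value, only a limit. Among the measured compounds shown here, the same holds across the series so far: the limit of > 25000 nM in this assay, at which 2 of the 2 values shown sit. Compound 3 `COc1cc(-c2cccc3nc(-c4ccc5cc[nH]c5c4)oc23)cc(OC)c1OC` changes one group of compound 2, putting 1H-indol-6-yl in place of 3-hydroxyphenyl on an aromatic carbon. For the measured compounds named here, the only measured step at this carbon is a step that the two limits leave unreadable from compound 1 to compound 2. That step gives no size to carry over, and neither group has yet produced a measurable value. A large change in this assay is therefore not expected, though any change that can be read would have to be towards a lower number, meaning a stronger inhibitor. The estimated step is an at least 1.2-fold lower number from compound 2 to compound 3 (0.09 log units; that floor lies within the scatter). Compound 3 is expected at about 20000 nM, with an estimated range of 4000 nM to 50000 nM, and it may well return only a limit again.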

Compound 3, half-maximal inhibitory concentration: > 25000 nM
Compound 3: no number, only a limit; the forecaster's own chance of this, stated with the estimate: 65%; middle value at least 1.2-fold (0.09 log units) from the limit.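

Compound 3 returns only a limit, as do compound 1 and compound 2, so no step among these three compounds can be read: the limit of > 25000 nM in this assay, at which 3 of the 3 values shown sit. The compounds shown leave open whether any group at this carbon can give a measurable value in this assay.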